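This account rests on a few compounds, and the source may have more. Where it says the series, first, only, none or still open, it means among the compounds named here.

Working notes on the series. Three compounds share one core and differ in a single group on an aromatic carbon: compound 1 `CN1CCCN(CCn2ccc3ccc(Br)cc32)CC1`, compound 2 `CN1CCCN(CCn2ccc3ccc(C(N)=O)cc32)CC1` and compound 3 `CN1CCCN(CCn2ccc3ccc(OCc4ccccc4)cc32)CC1`. In an assay on HEK293 cells for binding affinity to 5-hydroxytryptamine receptor 7 (Homo sapiens), read by radioligand binding, tested at 1 uM (a lower number here means less inhibition, a higher number more inhibition at the concentration tested (going by the name of the read-out)), compound 1 gives 93%, compound 2 gives 33% and compound 3 gives 28%. Compound 3 stands lowest of the three in this assay, but its gap to compound 2 is within the scatter, so the two cannot be ordered; only compound 1 stands clearly apart, a number 65 percentage points lower from compound 1 to compound 3 (beyond the scatter).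

Compound 4 `CCc1ccc2ccn(CCN3CCCN(C)CC3)c2c1` follows from compound 3 by ethyl in place of benzyloxy on an aromatic carbon. For the measured compounds named here, no measured step involves ethyl. Going by the values given here, the steps that bear on it are a number 65 percentage points lower from compound 1 to compound 3 (beyond the scatter), which is large, and a number 5 percentage points lower from compound 2 to compound 3 (within the scatter), which is not beyond the scatter. Benzyloxy leaving therefore removes the group that accompanied the large fall from compound 1; whether ethyl recovers that inhibition is unknown, so a rise is expected, of uncertain size: a number 32 percentage points higher from compound 3 to compound 4 (beyond the scatter). For compound 4 the expected value in this assay is 60%, with a range from 30% to 90%.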

Compound 4, a percentage reported as inhibition, at one concentration (the size of the read-out at that concentration, not a potency): 66%
The estimate for compound 4 lay 6 percentage points below the measured number; the range from low to high includes it.
By their numbers in this assay, from the lowest: compounds 3 and 2 (each within the scatter of the next); then compound 4; then compound 1.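

In this assay, ethyl on this aromatic carbon keeps the number well clear of the low pair, with a number 38 percentage points higher from compound 3 to compound 4 (beyond the scatter) and a number 33 percentage points higher from compound 2 to compound 4 (beyond the scatter), so replacing bromo here does not always bring the number down to the level of compound 2 and compound 3. Bromo still stands apart, with a number 27 percentage points lower from compound 1 to compound 4 (beyond the scatter), so ethyl recovers only part of the fall seen with carbamoyl and benzyloxy. Nothing available explains these differences.

As far as these compounds go, four groups at one position give no rule for ordering others, so it remains open whether methyl, propyl or chloro would stand nearer to compound 1 or to compound 4. An amine or a carboxylic acid at this carbon is equally unplaced, as is any effect of the same groups at another aromatic carbon of the shared core.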